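A few compounds are considered here, and "the series" means these few. Any claim that something is new, unique, unknown or untested is made for them only; others in the source may bear on it.

Compound 1 `O=C(Nc1cccc(-n2cc(-c3ccncc3)c(-c3ccc(Cl)c(O)c3)n2)c1)Nc1cccc(C(F)(F)F)c1` and compound 2 `O=C(Nc1cccc(-n2cc(-c3ccncc3)c(-c3ccc(Cl)c(O)c3)n2)c1)Nc1cc(C(F)(F)F)cc(C(F)(F)F)c1` share a core and differ at a single aromatic carbon. In a functional assay on PC-3 cells (Homo sapiens) for inhibition, read by sulforhodamine B assay, with a stated time of 48 h (a higher number here means a weaker inhibitor, a lower number a stronger inhibitor), compound 1 gives 950 nM, while compound 2 gives 320 nM. Within the data shown here, of these two numbers, compound 1 stands highest; the one measured step is a 3.0-fold lower number from compound 1 to compound 2 (0.47 log units; beyond the scatter), a second trifluoromethyl added to the ring that already carries one.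

Compound 3 `O=C(Nc1cccc(-n2cc(-c3ccncc3)c(-c3ccc(Cl)c(O)c3)n2)c1)Nc1ccc(Cl)c(C(F)(F)F)c1` has not yet been measured. It differs from compound 1 by chloro in place of hydrogen on an aromatic carbon. Among the measured compounds shown here, no measured step puts a chloro in this position, so the step from compound 1 to compound 2 is the only guide, and it shows that decorating this ring with one more group lowered the number modestly, beyond the scatter. The entering group here is the smaller of the two, so a smaller effect seems plausible.

Compound 3 is therefore expected to give about 500 nM in this assay, with a range of 220 nM to 1100 nM. The expected step is a 1.9-fold lower number from compound 1 to compound 3 (0.28 log units; within the scatter), estimated to be modest and possibly within the scatter.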

Compound 3, half-maximal inhibitory concentration: 590 nM
Compound 3: the middle estimate sits 1.2-fold (0.07 log units) below what was measured, within the range that was stated.
By their numbers in this assay, from the lowest: compounds 2, 3 and 1 (each within the scatter of the next, the first and the last beyond it).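

In this assay, chloro in place of hydrogen on the aromatic carbon ortho to the trifluoromethyl group and para to a large group gives a 1.6-fold lower number from compound 1 to compound 3 (0.21 log units; within the scatter), so at this position the chloro leaves compounds 1 and 3 indistinguishable in this read-out. Among these compounds, the only earlier step, a 3.0-fold lower number from compound 1 to compound 2 (0.47 log units; beyond the scatter), showed that adding a trifluoromethyl to this ring can move the number beyond the scatter, and the new step shows that adding one further group to the ring does not always do so. No measurement offered here explains why the two steps differ.

From the compounds shown here alone, it remains open whether another group on this same carbon, such as a methoxy, an amine or a carboxylic acid, would shift the number beyond the scatter in this assay, or whether a fluoro or bromo would behave as the chloro does. Also open, going by these compounds, is whether the chloro step would read the same on a different parent, since here it is seen only once, on compound 1.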